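A few compounds are considered here, and "the series" means these few. Any claim that something is new, unique, unknown or untested is made for them only; others in the source may bear on it.

Compound 1 `NS(=O)(=O)c1ccc(C(=O)N/N=C\c2ccc(Br)cc2)cc1` and compound 2 `NS(=O)(=O)c1ccc(C(=O)N/N=C\c2ccc(Cl)cc2)cc1` share one core and differ in a single place, (chloro in place of bromo on an aromatic carbon). In an ADME assay on MCF-10A cells (Homo sapiens) for antiproliferative activity, read by MTT assay (on this read-out higher numbers stand for weaker inhibition and lower numbers for stronger inhibition), compound 1 gives 27700 nM, while compound 2 gives 82000 nM. This single change produced a step of a 3.0-fold higher number from compound 1 to compound 2 (0.47 log units; beyond the scatter). Compound 3 `NS(=O)(=O)c1ccc(N/N=C(/CS(=O)(=O)c2ccccc2)c2ccc(Br)cc2)cc1` is built on a different core; how its core differs from that of compound 1 is not broken down here. In this assay, within the data shown here, compound 3 gives 12900 nM, the lowest of the three numbers measured so far. Compound 4 `NS(=O)(=O)c1ccc(N/N=C(/CS(=O)(=O)c2ccccc2)c2ccc(Cl)cc2)cc1` has not been measured yet. It stands to compound 3 as compound 2 stands to compound 1, carrying the same change, (chloro in place of bromo on an aromatic carbon), at a place described in exactly the same words. Among the measured compounds shown here, the only precedent for this change is the step of a 3.0-fold higher number from compound 1 to compound 2 (0.47 log units; beyond the scatter), which lies beyond the scatter. A step of similar size and direction is therefore expected for compound 4 in this assay, namely a 2.7-fold higher number from compound 3 to compound 4 (0.43 log units; beyond the scatter). For the measured compounds named here, there is only a single precedent, and it sits on another core. The expectation is held loosely. Compound 4 is estimated to give about 35000 nM, most likely between 15000 nM and 90000 nM.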

Compound 4, half-maximal inhibitory concentration: 28600 nM
Beside the measured number, compound 4's estimate is 1.2-fold (0.09 log units) above it, within the range that was stated.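

In this assay, putting chloro in place of bromo on the core of compound 3 gave a 2.2-fold higher number from compound 3 to compound 4 (0.35 log units; beyond the scatter), so the chloro compound is again the weaker inhibitor, as it was on the core of compound 1. Setting the two steps side by side shows that they agree in direction and that their sizes cannot be told apart: the same change on two cores in this assay, a 3.0-fold higher number (0.47 log units; beyond the scatter) from compound 1 to compound 2 and a 2.2-fold higher number (0.35 log units; beyond the scatter) from compound 3 to compound 4, 1.3-fold (0.13 log units) apart, within the scatter of two such steps. This suggests that the 4-bromophenyl to 4-chlorophenyl change carries over between these two cores, but two cores are a small sample, so it does not show that the step would hold on a third core, nor does it explain why the number moves.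

The compounds shown have only bromo or chloro at this place, so it remains open whether fluoro, iodo or a methyl group would continue the same direction. Going by these compounds, it also remains open how an amine or a carboxylic acid at that position would read in this assay.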